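The compounds below may be only part of what the source reports. "The series", "measured", "known", "first", "only" and "open" are said of these compounds alone.

Compound 1 `NNC(=O)C(N)CCSCCCCC(=O)O` and compound 2 `NC(CCSCCCCC(=O)O)C(=O)N1CCCCC1` share one core and differ only in the group on a carbonyl carbon. In an assay on isolated protein for inhibition of betaine--homocysteine S-methyltransferase 1 (Homo sapiens), with a stated time of 30 min, tested at 20 uM (on this read-out higher numbers stand for more inhibition at the one concentration tested (going by the name of the read-out) and lower numbers for less inhibition), compound 1 gives 28%, while compound 2 gives 9%. Among the compounds with values here, the single measured step, a number 19 percentage points lower from compound 1 to compound 2 (beyond the scatter), leaves compound 2 as the lower of the two numbers. Compound 3 `CS(=O)(=O)NC(=O)C(N)CCSCCCCC(=O)O` has not yet been measured; it differs from compound 2 in one place: methanesulfonamido in place of piperidin-1-yl on a carbonyl carbon. Within the data shown here, the one measured step bears on it directly, as it also exchanged the group on the same carbonyl carbon. Compound 3, like compound 1 with its aminoamino group, carries a hydrogen-bond donor at that position, and because compound 1 gives 28% a return toward that number is expected, an expected step of a number 13 percentage points higher from compound 2 to compound 3 (beyond the scatter). Compound 3 is therefore estimated at 22%, with a range from 5% to 40%.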

Compound 3, a percentage reported as inhibition, at one concentration (the size of the read-out at that concentration, not a potency): 67%
Compound 3: middle estimate off by 45 percentage points, on the low side; measured number outside the range, above it.
By their numbers in this assay, from the lowest: compound 2; then compound 1; then compound 3.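

In this assay the group on the carbonyl carbon carries far more weight than the first pair suggested: methanesulfonamido in place of piperidin-1-yl gives a number 58 percentage points higher from compound 2 to compound 3 (beyond the scatter) and takes the series well past compound 1. Methylsulfonyl in place of amino on the amide-type nitrogen gives a number 39 percentage points higher from compound 1 to compound 3 (beyond the scatter) and shows that the choice of group on that nitrogen matters, beyond the removal of piperidin-1-yl. Nothing available accounts for the size of this gain.

The compounds shown leave open whether a phenylsulfonyl or trifluoromethylsulfonyl group on that nitrogen would hold or raise the number, and how a carboxylic acid on the same carbonyl carbon would compare. Each number comes from a single concentration. The numbers give no potency for any of the three compounds.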